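The compounds below may be only part of what the source reports. "The series", "measured", "known", "first", "only" and "open" are said of these compounds alone.

Working notes on the series.

Of the compounds shown here, two have been measured in a functional assay on HCT-15 cells (Homo sapiens) for cytotoxicity; on this read-out higher numbers stand for an effect only at larger amounts of compound and lower numbers for an effect already at smaller amounts. Compound 1, `C=CCCCCCCCC#CC#CC(O)CC(C)=O`, in this assay gives 4.18 ug/mL. Compound 2, `C=CCCCCCC#CC#C/C(O)=C\C(C)=O`, in this assay gives 4.56 ug/mL. Compound 2 thus stands at the upper of the two numbers recorded so far, but its distance from compound 1 lies within the usual scatter, so the two values are treated as indistinguishable. Among the compounds with values here, no step between measured compounds that differ in a single place is available, so nothing in the data shows how any one structural change moves the read-out.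

Compound 3, `C=CCCCCCC#CC#C/C(O)=C/C(C)=O`, is the next candidate for this assay. The change from compound 2 to compound 3 is: the two compounds have the same atoms and bonds and differ only in configuration as drawn: 1 of 1 stereo elements differ; a double bond is drawn E in compound 2 and Z in compound 3. With no comparable change among the measured compounds, there is no basis for expecting a shift beyond the scatter in either direction. The estimated step of a 1.0-fold lower number from compound 2 to compound 3 (0.01 log units; within the scatter) is therefore expected to be essentially none. Compound 3 is expected to give about 4.5 ug/mL, with a range from 2.2 ug/mL to 9 ug/mL.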

Compound 3, concentration for half-maximal effect: 11.3 ug/mL
Estimate against measurement, compound 3: 2.5-fold (0.40 log units) below, and the stated range ends below it.
By their numbers in this assay, from the lowest: compounds 1 and 2 (each within the scatter of the next); then compound 3.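

In this assay the series now holds its first step between compounds that differ in one place, and that step is a 2.5-fold higher number from compound 2 to compound 3 (0.39 log units; beyond the scatter). It shows that the configuration of the double bond alone can move the read-out, with the form drawn Z showing its effect only at larger amounts of compound, so identical atoms and bonds do not fix the number on their own. The step can be tied to that double bond and to nothing else, because no other feature separates the pair: the fact that compounds 2 and 3 differ only in the configuration as drawn

The compounds shown leave open whether the same change of configuration moves the read-out by a similar amount on a longer chain, as this single pair gives only one reading of it. They also leave open how the read-out responds when the hydroxyl group or the carbonyl gives way to an amine or a carboxylic acid, with the double bond held in either configuration.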